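Trifluoromethyl on the pendant ring of the amide series

The compounds below may be only part of what the source reports. "The series", "measured", "known", "first", "only" and "open" are said of these compounds alone.

Compound 1 `CCNC(=O)CCc1cccc2c1B(O)OC2` carries the shared core with a short ethylamide. In a functional assay on HCT-116 cells (Homo sapiens) for antiproliferative activity, read by MTT assay, with a stated time of 72 h (on this read-out lower numbers stand for stronger inhibition and higher numbers for weaker inhibition), compound 1 gives only a limit, > 100000 nM, so no number is known for it.

Compound 2 `O=C(CCc1cccc2c1B(O)OC2)Nc1cccc(-c2cccc(F)c2)c1` extends the amide to a biaryl amine bearing a fluoro substituent; in this assay compound 2 gives 460 nM. Compound 3 `O=C(CCc1cccc2c1B(O)OC2)Nc1cccc(-c2cccc(OC(F)(F)F)c2)c1` replaces that fluoro with trifluoromethoxy on an aromatic carbon; in this assay compound 3 gives 310 nM. The step of a 1.5-fold lower number from compound 2 to compound 3 (0.17 log units; within the scatter) is within the scatter, so the two values are indistinguishable. Compound 2 therefore stands at the higher of the two numbers, with compound 3 nearest, and the remaining value of the series being a limit (the limit of > 100000 nM in this assay, at which 1 of the 3 values shown sits).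

Compound 4 `O=C(CCc1cccc2c1B(O)OC2)Nc1cccc(-c2ccc(C(F)(F)F)cc2)c1` is not yet measured. It differs from compound 2 in one place (4-(trifluoromethyl)phenyl in place of 3-fluorophenyl on an aromatic carbon). Going by the values given here, the only measured step that bears on this change is the one from compound 2 to compound 3, a swap of one fluorine-bearing substituent for another on the pendant ring, which stayed within the scatter. On that basis no step beyond the scatter is expected in this assay, in either direction; the expected step is a 1.1-fold lower number from compound 2 to compound 4 (0.04 log units; within the scatter). Compound 4 is estimated to give 420 nM, with a range from 150 nM to 1200 nM.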

Compound 4, half-maximal inhibitory concentration: 550 nM
Beside the measured number, compound 4's estimate is 1.3-fold (0.12 log units) below it; measured number inside the range.
By their numbers in this assay, from the lowest: compounds 3, 2 and 4 (each within the scatter of the next). At a limit, above all of these: compound 1.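

The pendant ring in this amide series takes a larger change than the earlier swap showed: that step replaced fluoro with trifluoromethoxy at the same ring place, whereas 4-(trifluoromethyl)phenyl in place of 3-fluorophenyl changes both the group and where it sits on the ring. In this assay this change gives (a 1.2-fold higher number from compound 2 to compound 4 (0.08 log units; within the scatter)), and the earlier step gives (a 1.5-fold lower number from compound 2 to compound 3 (0.17 log units; within the scatter)), so neither the kind of fluorine-bearing group nor this change of its ring place separates compounds 2, 3 and 4 on the present numbers. No measured property shown here bears on this result.

From the compounds shown here alone, all three of these pendant rings carry fluorine, so it remains open how the read-out would respond to an unsubstituted phenyl ring or to an amine or a carboxylic acid at the same place. Going by these compounds, compound 1 gives only a limit (> 100000 nM), and the ground between its ethylamide and the biaryl amides, such as a single phenyl amide or a longer chain, also remains open.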